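Moving the Fluorine on a Hydroxy-Bearing Core

The source may report more compounds than this note shows. Statements on the series, on what has been measured and on what is new or still open speak of the compounds shown alone.

Compound 1 `CC(=O)Nc1ccc2oc(-c3cccc(F)c3)cc(=O)c2c1` and compound 2 `CC(=O)Nc1ccc2oc(-c3ccc(F)cc3)cc(=O)c2c1` share a core. In an ADME assay on MT4 cells (Homo sapiens) for cytotoxicity, read by MTT assay, with a stated time of 4 days (a higher number here means that more compound is tolerated, a lower number that less compound is tolerated), compound 1 gives 240000 nM and compound 2 gives 203000 nM, a step of a 1.2-fold lower number from compound 1 to compound 2 (0.07 log units; within the scatter), brought about by 4-fluorophenyl in place of 3-fluorophenyl on an aromatic carbon. Compound 3 `CC(=O)Nc1ccc2oc(-c3cccc(F)c3)c(O)c(=O)c2c1` differs from compound 1 by hydroxy in place of hydrogen on an aromatic carbon; in this assay compound 3 gives 26500 nM, a step of a 9.1-fold lower number from compound 1 to compound 3 (0.96 log units; beyond the scatter), which leaves compound 3 with the lowest number of the three. Compound 4 `CC(=O)Nc1ccc2oc(-c3ccc(F)cc3)c(O)c(=O)c2c1` has not been measured. It differs from compound 3 by 4-fluorophenyl in place of 3-fluorophenyl on an aromatic carbon, the same kind of change as that between compound 1 and compound 2, though here the place is also ortho to a hydroxy group. The earlier step of a 1.2-fold lower number from compound 1 to compound 2 (0.07 log units; within the scatter) stayed within the scatter. On that ground the expected step in this assay is a 1.2-fold lower number from compound 3 to compound 4 (0.06 log units; within the scatter). Compound 4 is therefore estimated at 23000 nM, with a range from 10000 nM to 55000 nM.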

Compound 4, half-maximal cytotoxic concentration: 34100 nM
Estimate against measurement, compound 4: 1.5-fold (0.17 log units) below, and the stated range covers the measured number.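

In this assay, 4-fluorophenyl in place of 3-fluorophenyl on the hydroxy-bearing core gives a 1.3-fold higher number from compound 3 to compound 4 (0.11 log units; within the scatter), and this exchange carries across the two cores with no difference beyond the scatter: the same change on two cores in this assay, a 1.2-fold lower number (0.07 log units; within the scatter) from compound 1 to compound 2 and a 1.3-fold higher number (0.11 log units; within the scatter) from compound 3 to compound 4, 1.5-fold (0.18 log units) apart, within the scatter of two such steps. Hydroxy in place of hydrogen on the core of compound 2 gives a 6.0-fold lower number from compound 2 to compound 4 (0.77 log units; beyond the scatter), so this change also carries over, and here the step lies beyond the scatter on both cores: the same change on two cores in this assay, a 9.1-fold lower number (0.96 log units; beyond the scatter) from compound 1 to compound 3 and a 6.0-fold lower number (0.77 log units; beyond the scatter) from compound 2 to compound 4, 1.5-fold (0.18 log units) apart, within the scatter of two such steps. This agreement rests on only these four compounds in a single assay, and it does not show that either change would carry to any other core.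

The compounds shown leave open whether an amine or a methoxy group in place of the hydroxy group would give a step of like size. As far as these compounds go, it also remains open whether chlorine in place of the fluorine would leave the number as little changed.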